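Aryl swap on the fused core: compound 3 to compound 4

This account rests on a few compounds, and the source may have more. Where it says the series, first, only, none or still open, it means among the compounds named here.

Measured so far in an assay on isolated protein for agonist activity at Free fatty acid receptor 1 (Homo sapiens); on this read-out higher numbers stand for an effect only at larger amounts of compound and lower numbers for an effect already at smaller amounts:
compound 1 `CC#CC(CC(=O)O)c1ccc(OCc2ccn3cc(-c4ccc(C5CCCCC5)cc4)nc3c2)cc1`: 559 nM
compound 2 `CC#CC(CC(=O)O)c1ccc(OCc2ccn3cc(-c4ccc(C)cc4C)nc3c2)cc1`: 503 nM
compound 3 `CC#CC(CC(=O)O)c1ccc(OCc2ccc3nc(-c4ccccc4C)cn3c2)cc1`: 389 nM

Compound 3 has the lowest of the three numbers, but its gaps to compound 2 and to compound 1 both lie within the scatter, so the three stand together on this assay.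

Compound 4 `CC#CC(CC(=O)O)c1ccc(OCc2ccc3nc(-c4ccc(F)cc4)cn3c2)cc1` differs from compound 3 by 4-fluorophenyl in place of 2-methylphenyl on an aromatic carbon. Within the data shown here, only one measured step touches the aryl group on this ring: a 1.1-fold lower number from compound 1 to compound 2 (0.05 log units; within the scatter), a change of aryl substituents that left the number essentially where it was. Nothing measured separates a 2-methylphenyl from a 4-fluorophenyl at this place, so the expectation for the step to compound 4 rests on that single neutral step and is a step of no more than the scatter, in either direction, expected as a 1.1-fold higher number from compound 3 to compound 4 (0.03 log units; within the scatter).

For compound 4 the estimate in this assay is 420 nM, with a range from 200 nM to 900 nM.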

Compound 4, half-maximal effective concentration: 623 nM
For compound 4 the middle estimate is 1.5-fold (0.17 log units) below the measured one; the measured number falls inside the stated range.
By their numbers in this assay, from the lowest: compounds 3, 2, 1 and 4 (each within the scatter of the next).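

In this assay, 4-fluorophenyl in place of 2-methylphenyl on this aromatic carbon, next to the ring nitrogen, gives a 1.6-fold higher number from compound 3 to compound 4 (0.20 log units; within the scatter). Among these compounds, this is the first measured aryl exchange on the core of compound 3, and it adds to a 1.1-fold lower number from compound 1 to compound 2 (0.05 log units; within the scatter) on the other core: neither step leaves the scatter, so the two aryl changes measured so far do not separate the compounds. No measurement at hand gives a reason for the size of this step.

The exchange alters both the substituent and its place on the phenyl ring, so the contribution of each remains unresolved, and an unsubstituted phenyl group would give a reference point. Also open, going by these compounds, is whether an amine or a morpholine ring in place of the aryl group at this carbon would move the number beyond the scatter.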